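The source may report more compounds than this note shows. Statements on the series, on what has been measured and on what is new or still open speak of the compounds shown alone.

Compound 1 `CCCCCCc1cc2c(=O)n(CC3CC3)cnc2s1`: in an ADME assay on MCF7 cells (Homo sapiens) for cytotoxicity, read by MTT assay, with a stated time of 11 days (a lower number here means a stronger inhibitor of growth, a higher number a weaker inhibitor of growth), compound 1 gives 24.8 ug/mL.
Compound 2 `CCCCCCCc1cc2c(=O)n(CC3CC3)cnc2s1`: in this assay compound 2 reaches only the assay limit > 100 ug/mL.
Compound 3 `CCCCCCCCCCc1cc2c(=O)n(CCO)cnc2s1`: in this assay compound 3 likewise reaches only the assay limit > 100 ug/mL.

Compound 2 thus stands at the limit (the limit of > 100 ug/mL in this assay, at which 2 of the 3 values shown sit), and only compound 1 gives a number at all. For the measured compounds named here, the single measured step, an at least 4.0-fold higher number from compound 1 to compound 2 (0.60 log units; beyond the scatter), concerns the chain and not the group on the aromatic nitrogen. Compound 4 `CCCCCCCc1cc2c(=O)n(CCN=[N+]=[N-])cnc2s1` differs from compound 2 by azidomethyl in place of cyclopropyl on a saturated chain carbon bound to an aromatic nitrogen. Going by the values given here, no measured step touches that position; compound 3 carries a different group there and sits at the limit as well. For compound 4 a step that the limit leaves unreadable from compound 2 to compound 4 in this assay is expected, that is none beyond the scatter. Compound 4 is therefore estimated at 120 ug/mL, range 40 ug/mL to 300 ug/mL, most probably again reported only as a limit.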

Compound 4, concentration for 50% growth inhibition: > 100 ug/mL
Compound 4 was reported as a limit; the forecaster's own chance of this, stated with the estimate: 70%; the middle value does not contradict the limit.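

Compound 2 and compound 4 both give only a limit in this assay, so no step between them can be read: the limit of > 100 ug/mL in this assay, at which 3 of the 4 values shown sit.
From the compounds shown here alone, whether azidomethyl in place of cyclopropyl changes growth inhibition at all remains open.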